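The source may report more compounds than this note shows. Statements on the series, on what has been measured and on what is new or still open speak of the compounds shown alone.

Measured in a functional assay on A2780 cells (Homo sapiens) for cytotoxicity, read by MTT assay, with a stated time of 24 h; on this read-out higher numbers stand for weaker inhibition and lower numbers for stronger inhibition:
Compound 1 `CC(C)c1cc2c(cc1O)[C@]13CCC[C@](C)(CO[C@H]1O)[C@@H]3CC2`: > 10000 nM, a limit
Compound 2 `CO[C@@H]1OC[C@@]2(C)CCC[C@@]13c1cc(O)c(C(C)C)cc1CC[C@@H]23`: > 10000 nM, a limit

Compound 2 has no numerical value in this assay, only the limit > 10000 nM. Among the compounds with values here, the one further value, that of compound 1, is also a limit. The evidence therefore comes down to the limit of > 10000 nM in this assay, at which 2 of the 2 values shown sit.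

Compound 3 `CCO[C@@H]1OC[C@@]2(C)CCC[C@@]13c1cc(O)c(C(C)C)cc1CC[C@@H]23` differs from compound 2 by turning methoxy to ethoxy: methyl in place of hydrogen on a saturated chain carbon bound to an oxygen on a saturated carbon. This is methyl in place of hydrogen on a saturated chain carbon bound to an oxygen on a saturated carbon.

Within the data shown here, the one measured step that bears on this change is methyl in place of hydrogen on an oxygen on a saturated carbon, a step that the two limits leave unreadable from compound 1 to compound 2. It offers no size to carry over and no direction. No step beyond the usual scatter is therefore expected in this assay, and a further report of a limit seems likely because of the limit of > 10000 nM in this assay, at which 2 of the 2 values shown sit.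

The expected outcome is a step that the limit leaves unreadable from compound 2 to compound 3. For compound 3 the estimate is 15000 nM, with an expected range of 7000 nM to 40000 nM.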

Compound 3, half-maximal inhibitory concentration: > 10000 nM
Compound 3 gave a limit, no number; the forecaster's own chance of this, stated with the estimate: 90%; the middle value lies beyond the limit too.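

In this assay no step can be read among compound 1, compound 2 and compound 3, since every value is a limit and none is a number: the limit of > 10000 nM in this assay, at which 3 of the 3 values shown sit.

The compounds shown leave open whether turning methoxy to ethoxy, or any other difference among these three, changes the cytotoxicity at all.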